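A few compounds are considered here, and "the series" means these few. Any claim that something is new, unique, unknown or untested is made for them only; others in the source may bear on it.

Measured so far:
compound 1 `CCCCOC1=C(C(=O)c2ccccc2)C(c2ccc(Br)cc2)N(CCCn2ccnc2)C1=O`: 11600 nM
compound 2 `CCOc1ccc(NC2=C(C(=O)c3ccccc3)C(c3ccc(Br)cc3)N(CCCn3ccnc3)C2=O)cc1`: 30900 nM

Both numbers come from a functional assay on SAOS-2 cells (Homo sapiens) for antiproliferative activity, read by MTT assay, with a stated time of 72 h; on this read-out lower numbers stand for stronger inhibition and higher numbers for weaker inhibition. Compound 1 holds the lowest of the two numbers; the nearest is compound 2, reached by a 2.7-fold higher number from compound 1 to compound 2 (0.43 log units; beyond the scatter), a modest step that nevertheless lies beyond the scatter. That step replaces the butoxy group with an arylamino group on a double-bonded ring carbon of the shared core.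

The unmeasured compound 3 `O=C(C1=C(Nc2ccc(OC(F)(F)F)cc2)C(=O)N(CCCn2ccnc2)C1c1ccc(Br)cc1)c1ccccc1` departs from compound 1 at the same place: (4-(trifluoromethoxy)phenyl)amino in place of butoxy on a double-bonded ring carbon. This is the same kind of replacement as that from compound 1 to compound 2, the entering (4-(trifluoromethoxy)phenyl)amino group resembling the (4-ethoxyphenyl)amino group of compound 2. Among the measured compounds shown here, the one measured step that bears on the change is a 2.7-fold higher number from compound 1 to compound 2 (0.43 log units; beyond the scatter). For the measured compounds named here, no measured pair informs the trifluoromethoxy variant on its own, so a step in the same direction and of comparable size is the working expectation, with room for it to fall back within the scatter. Compound 3 is therefore expected to give 25000 nM in this assay, between 10000 nM and 60000 nM, the expected step being a 2.2-fold higher number from compound 1 to compound 3 (0.33 log units; beyond the scatter).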

Compound 3, half-maximal inhibitory concentration: 17900 nM
Compound 3: the middle estimate sits 1.4-fold (0.15 log units) above what was measured, and the stated range covers the measured number.
By their numbers in this assay, from the lowest: compounds 1, 3 and 2 (each within the scatter of the next, the first and the last beyond it).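

In this assay, the exchange of butoxy for an arylamino group on the double-bonded ring carbon does not always separate from the butoxy compound: with the (4-(trifluoromethoxy)phenyl)amino group there is a 1.5-fold higher number from compound 1 to compound 3 (0.19 log units; within the scatter), so the step beyond the scatter seen with compound 2 is not a general result of placing an arylamino group here. Trifluoromethyl in place of ethyl on the oxygen on the aromatic ring gives a 1.7-fold lower number from compound 2 to compound 3 (0.24 log units; within the scatter), which leaves compound 3 unresolved from both neighbours and means that the three compounds do not fall into two clear groups, with only compound 1 and compound 2 lying apart. Nothing at hand accounts for these numbers.

Open, going by these compounds, is how the oxygen link and the nitrogen link compare with the side chain held constant, as a butylamino group set against butoxy, or a plain phenylamino group set against the two substituted ones, would show. On these data alone, the benzoyl, 4-bromophenyl and 3-(1H-imidazol-1-yl)propyl groups are the same in all three compounds, so what each contributes to the read-out remains open.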